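The compounds below may be only part of what the source reports. "The series", "measured", "known", "first", "only" and "open" are said of these compounds alone.

Measured so far:
compound 1 `CCC(C(=O)N1CCN(c2cccc(Cl)c2)CC1)N1C(=O)CCC1=O` — 50%
compound 2 `CC(C(=O)N1CCN(c2cccc(Cl)c2)CC1)N1C(=O)CCC1=O` — 50%
compound 3 `CCC(C(=O)N1CCN(c2ccccc2)CC1)N1C(=O)CCC1=O` — 25%

In a functional assay on the whole organism (strain Swiss) with Mus musculus as the target, in the maximal electroshock model, with a stated time of 0.25 h, at a dose of 100 mg/kg by the intraperitoneal route (a lower number here means a weaker effect, a higher number a stronger effect of the compound at the dose given), compound 2 stands level with compound 1 at the digits shown, the two together the highest of the three numbers; the one step among the measured pairs that changes the number is a number 25 percentage points lower from compound 1 to compound 3 (beyond the scatter).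

Compound 4 `CC(C(=O)N1CCN(c2ccc(F)cc2)CC1)N1C(=O)CCC1=O` is not yet measured. Against compound 2 it carries 4-fluorophenyl in place of 3-chlorophenyl on an amine nitrogen in a ring.

Among the measured compounds shown here, two measured steps bear on this. The first, no change at the digits printed from compound 1 to compound 2 (within the scatter), shows that the change on the saturated chain carbon that separates compound 2 from compound 1 leaves the number alone, so compound 2 can be read with compound 1. The second, a number 25 percentage points lower from compound 1 to compound 3 (beyond the scatter), shows that taking the chloro off the aromatic ring costs a modest amount. Compound 4 keeps a halogen on the ring, but neither a fluoro nor the 4-position is covered by any measured pair, so the step from compound 2 to compound 4 is not a repeat of a known one. A drop smaller than the chloro-to-hydrogen step is expected, with wide uncertainty.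

For compound 4 the expected step is a number 15 percentage points lower from compound 2 to compound 4 (beyond the scatter), giving an estimate of 35% in this assay, within 10% to 60%.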

Compound 4, a percentage reported as activity, at one dose (the size of the read-out at that dose, not a potency): 75%
The estimate for compound 4 lay 40 percentage points below the measured number; the measured number lies above the stated range.
By their numbers in this assay, from the lowest: compound 3; then compounds 1 and 2 (each within the scatter of the next); then compound 4.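

In this assay, among the compounds shown here, the swap to 4-fluorophenyl on an amine nitrogen in a ring gives a number 25 percentage points higher from compound 2 to compound 4 (beyond the scatter) and so shows that this place can raise the read-out as well as lower it, whereas the only earlier step at this aryl group was the loss seen in a number 25 percentage points lower from compound 1 to compound 3 (beyond the scatter) on taking off the chloro. The 3-chlorophenyl of compound 2 is therefore not the upper end of what this place allows, and the gain arrives with the same count of heavy atoms in the leaving and entering groups and with no hydrogen-bond donors or acceptors on either. Nothing measured here gives a reason for the rise in the read-out, so the step stands as an observation only.

The halogen and its place on the aromatic ring change together in this single step, so the contribution of the fluoro cannot be separated from that of the 4-position, and 4-chlorophenyl and 3-fluorophenyl are the two groups that would pull them apart. Also open, from the compounds shown here alone, is whether the gain carries over to the longer chain on the saturated carbon of compound 1, and whether a larger group at the 4-position of the phenyl, such as methoxy or trifluoromethyl, keeps it.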